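The source may hold more compounds than are shown below. What is called first, only, known or untested is meant among the compounds shown, and "the series" means these compounds.

Measured compounds:
- compound 1, `CS(=O)(=O)c1ccc(-c2cnc3[nH]cc(-c4nnc(-c5ccncc5)o4)c(=O)c3c2)cc1`: 2.16%
- compound 2, `CS(=O)(=O)c1ccc(-c2cnc3[nH]cc(-c4nnc(-c5ccc(F)cc5)o4)c(=O)c3c2)cc1`: 2.55%
- compound 3, `CS(=O)(=O)c1ccc(-c2cnc3[nH]cc(-c4nnc(-c5ccccc5)o4)c(=O)c3c2)cc1`: 4.38%

These three compounds share one core and differ only in the aryl group on the oxadiazole. In a functional assay on KB cells (Homo sapiens) for inhibition, read by MTT assay, with a stated time of 24 h, tested at 5 uM (a lower number here means less inhibition of growth, a higher number more inhibition of growth at the concentration tested), compound 1 gives 2.16%, compound 2 gives 2.55% and compound 3 gives 4.38%. Compound 3 holds the highest of the three numbers, but the gap to its nearest neighbour, a number 1.8 percentage points higher from compound 2 to compound 3 (within the scatter), and the gap to the furthest, a number 2.2 percentage points higher from compound 1 to compound 3 (within the scatter), both lie within the scatter, so the three values cannot be told apart.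

Compound 4, `CS(=O)(=O)c1ccc(-c2cnc3[nH]cc(-c4nnc(-c5ccc(Cl)cc5)o4)c(=O)c3c2)cc1`, is the next step from compound 3: chloro in place of hydrogen on an aromatic carbon. For the measured compounds named here, the step that bears most directly on it is the one from compound 2 to compound 3, where a different halogen at the same place gave a number 1.8 percentage points higher from compound 2 to compound 3 (within the scatter), inside the scatter. The exchange of pyridin-4-yl for phenyl, a number 2.2 percentage points higher from compound 1 to compound 3 (within the scatter), likewise moved nothing beyond the scatter. Nothing in these data therefore points to a step beyond the scatter in this assay when chloro replaces hydrogen. Compound 4 is expected to give about 4.5%, between -5% and 14%, which means an expected step of a number 0.1 percentage points higher from compound 3 to compound 4 (within the scatter).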

Compound 4, percent growth inhibition at one concentration: 2.15%
The estimate for compound 4 lay 2.4 percentage points above the measured number, and the stated range covers the measured number.
By their numbers in this assay, from the lowest: compounds 4, 1, 2 and 3 (each within the scatter of the next).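

In this assay, chloro in place of hydrogen on the aromatic carbon para to a large group gave a number 2.2 percentage points lower from compound 3 to compound 4 (within the scatter) and chloro in place of fluoro at that same carbon gave a number 0.4 percentage points lower from compound 2 to compound 4 (within the scatter) so that a second halogen at this place, and a larger one by its atom, now stands alongside fluoro with no step beyond the scatter. The exchange of the whole ring, 4-chlorophenyl in place of pyridin-4-yl, gave a number 0 percentage points lower from compound 1 to compound 4 (within the scatter) and with this fourth aryl group every step among the compounds shown lies within the scatter, so that this position has so far shown no response to any change tried on it. Nothing in the data shown accounts for this flat picture.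

The compounds shown leave open whether a group of another kind at this carbon, such as an amine, a carboxylic acid or a longer chain like butoxy, would give a step beyond the scatter. They also leave open whether changes elsewhere on the shared core, for instance in place of the methylsulfonyl group, would move the number at all.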